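A few compounds are considered here, and "the series" means these few. Any claim that something is new, unique, unknown or untested is made for them only; others in the source may bear on it.

Among the compounds with values here, in a functional assay on MCF7 cells (Homo sapiens) for cytotoxicity, read by fluorescence, with a stated time of 72 h (a lower number here means a stronger inhibitor, a higher number a weaker inhibitor), compound 1 `Cn1nc(N)c(/N=N/c2ccncc2)c1N` gives 37700 nM and compound 2 `Nc1n[nH]c(N)c1/N=N/c1ccc(O)cc1` gives 62000 nM, so compound 2 stands within the scatter of the only other number available. Compound 3 `CC(=O)n1nc(N)c(/N=N/c2ccc(O)cc2)c1N` differs from compound 2 at one place: acetyl in place of hydrogen on an aromatic nitrogen. Within the data shown here, no measured pair shows what this change does, so no step beyond the scatter is expected in this assay, in either direction. The estimated 1.6-fold lower number from compound 2 to compound 3 (0.19 log units; within the scatter) stays within that scatter. Compound 3 is expected at 40000 nM, with a likely range from 13000 nM to 100000 nM.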

Compound 3, half-maximal inhibitory concentration: 44900 nM
The estimate for compound 3 lay 1.1-fold (0.05 log units) below the measured number; low and high end bracket the measured number.
By their numbers in this assay, from the lowest: compounds 1, 3 and 2 (each within the scatter of the next).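

In this assay, within the data shown here, acetyl in place of hydrogen on an aromatic nitrogen gives a 1.4-fold lower number from compound 2 to compound 3 (0.14 log units; within the scatter) and this is the first step read at this position. It shows that this nitrogen can carry acetyl instead of hydrogen with no difference beyond the scatter in this cytotoxicity read-out. No evidence at hand bears on this result. Still open, from the compounds shown here alone, is whether a benzoyl group or a longer acyl chain on this nitrogen would move the number beyond the scatter. Also open, going by these compounds, is whether a carboxylic acid on that position would do so.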